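Amino in Place of Chloro: Expected Shift in Cytotoxicity

The source may report more compounds than this note shows. Statements on the series, on what has been measured and on what is new or still open speak of the compounds shown alone.

Of the compounds shown here, three have been measured in an ADME assay on KB cells (Homo sapiens) for cytotoxicity; a lower number here means that less compound is needed, a higher number that more compound is needed for the effect. Compound 1 `Nc1nc(O)c2ncn([C@@H]3C[C@H](CO)[C@@H](O)C3)c2n1` gives 95 ug/mL in this assay. Compound 3 `Nc1nc(Cl)c2ncn(C3CC(O)C(CO)C3)c2n1` gives 62 ug/mL, the lowest of the two numbers shown; its nearest neighbour is compound 1, a gap that lies within the usual scatter, so the two cannot be put in order. Compound 2 `Nc1nc(N)c2nnn(C3CC(O)C(CO)C3)c2n1` reaches only a limit of this assay, > 100 ug/mL, and so supplies no number. No two of these compounds differ in a single place, so no measured step is available to lean on.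

Compound 4 `Nc1nc(N)c2ncn(C3CC(O)C(CO)C3)c2n1` is the next to be measured. It differs from compound 3 in one place: amino in place of chloro on an aromatic carbon. Going by the values given here, since no measured step of this kind is at hand, the expected change is a modest move toward a higher number, a 1.5-fold higher number from compound 3 to compound 4 (0.16 log units; within the scatter), small enough that it may still fall within the scatter. Compound 4 is therefore expected to give about 90 ug/mL in this assay, with a range from 45 ug/mL to 200 ug/mL.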

Compound 4, concentration for half-maximal effect: > 100 ug/mL
Compound 4 ended at the assay's limit (the forecaster's own chance of this, stated with the estimate: 40%); middle value at least 1.1-fold (0.04 log units) from the limit.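

Swapping chloro for amino on this aromatic carbon, opposite the ring nitrogen, gives the first step that can be read at this position in this assay (an at least 1.6-fold higher number from compound 3 to compound 4 (0.20 log units; that floor lies within the scatter)). The amino group brings one hydrogen-bond donor and one hydrogen-bond acceptor that chloro lacks, and this change gives no sign of a lower number. The step is only a floor, and since that floor lies within the scatter, this pair cannot show how large the true change is, as the upper end of the assay cuts the reading off: the limit of > 100 ug/mL in this assay, at which 2 of the 4 values shown sit.

Going by these compounds, how far compound 4 really lies past that limit remains unknown. Also open, on these data alone, is whether a methylamino group or a methoxy group on this same carbon would give a number that can be read within the range of this assay.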